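A few compounds are considered here, and "the series" means these few. Any claim that something is new, unique, unknown or untested is made for them only; others in the source may bear on it.

Compounds tested in a functional assay on A-431 cells (Homo sapiens) for antiproliferative activity, read by MTT assay, with a stated time of 72 h; on this read-out lower numbers stand for stronger inhibition and higher numbers for weaker inhibition:

- compound 1 `CN1CCN(c2ccc(Nc3ncc4nc(Nc5ccc(F)cc5)n([C@H]5CCCNC5)c4n3)cc2)CC1`: "not determined" (no result reported)
- compound 2 `CN1CCN(c2ccc(Nc3ncc4nc(Nc5ccc(F)cc5)n([C@H]5CCN(C(=O)OC(C)(C)C)C5)c4n3)cc2)CC1`: "not determined" (no result reported)
- compound 3 `CN1CCN(c2ccc(Nc3ncc4nc(Nc5ccccc5)n([C@H]5CCN(S(=O)(=O)C6CC6)C5)c4n3)cc2)CC1`: 1670 nM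

Of these three entries, only compound 3 carries a number, 1670 nM. With nothing to rank it against, it can be called neither strong nor weak within this set. Compound 1 and compound 2 both contain the (4-fluorophenyl)amino group, but neither has a result, so they offer no measured comparison. For the measured compounds named here, no measured pair shows what any single structural change does in this assay.

The next compound, compound 4 `CN1CCN(c2ccc(Nc3ncc4nc(Nc5ccc(F)cc5)n([C@H]5CCN(S(=O)(=O)C6CC6)C5)c4n3)cc2)CC1`, differs from compound 3 in one place: fluoro in place of hydrogen on an aromatic carbon. This is fluoro in place of hydrogen on an aromatic carbon, para to a large group, turning phenyl into 4-fluorophenyl. The rest of the structure stays the same.

The only anchor for a prediction is compound 3 at 1670 nM. Going by the values given here, with no measured step to draw on, the expectation in this assay is for no shift beyond the scatter and no firm direction. The estimated change is small, a 1.1-fold lower number from compound 3 to compound 4 (0.05 log units; within the scatter). Compound 4 is expected at 1500 nM, with an estimated range of 550 nM to 4000 nM.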

Compound 4, half-maximal inhibitory concentration: 1670 nM
The estimate for compound 4 lay 1.1-fold (0.05 log units) below the measured number; low and high end bracket the measured number.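

In this assay, for the compounds shown here, the first step between measured compounds that differ in one place reads no change at the digits printed from compound 3 to compound 4 (within the scatter): fluoro in place of hydrogen on an aromatic carbon, para to a large group, turning phenyl into 4-fluorophenyl. The (4-fluorophenyl)amino group, which had appeared only in compounds without a result, now has a number, with compound 4 at 1670 nM, and this single swap leaves the read-out where it stood, within the scatter. No measurement shown here offers a reason for this result.

The compounds shown do not tell whether this place would respond to a different kind of group, such as chloro, methoxy, nitrile or an amine, since hydrogen and fluoro are the only two groups compared there. They also leave open what the group on the saturated ring contributes to the read-out, since the only other variations of that part, the free ring amine in compound 1 and the tert-butyl carbamate in compound 2, have no result that could be set against compound 3 or compound 4.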